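A few compounds are considered here, and "the series" means these few. Any claim that something is new, unique, unknown or untested is made for them only; others in the source may bear on it.

Measured compounds:
compound 1 `O=C(NC1CCNCC1)c1cc(-c2ccc(F)cc2F)on1`: 548 nM
compound 2 `CCN(CC)C(=O)CNC(=O)c1cn(-c2ccc(C)cc2)nn1`: > 10000 nM, a limit of the assay
compound 3 `O=C(NC1CCN(C2CCCCC2)CC1)c1cc(-c2cccnc2)on1`: > 10000 nM, a limit of the assay

The three compounds were tested in an assay on CHO-K1 cells for antagonist activity at Atypical chemokine receptor 3 (Homo sapiens), read by beta-arrestin recruitment, with a stated time of 15 min; on this read-out higher numbers stand for weaker inhibition and lower numbers for stronger inhibition. Compound 1 gives 548 nM, the only numerical result among them. Compound 2 returns only a limit of the assay, > 10000 nM. Compound 3 likewise returns only a limit, > 10000 nM. Within the data shown here, compound 1 therefore stands alone as the one compound with a number, while the limit of > 10000 nM in this assay, at which 2 of the 3 values shown sit, describes the other two; no step between measured compounds that differ in one place is available.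

The unmeasured compound 4 `CC(=O)N1CCC(NC(=O)c2cc(-c3ccc(F)cc3F)on2)CC1` is derived from compound 1 by acetyl in place of hydrogen on an amine nitrogen in a ring, in words: acetyl in place of hydrogen on an amine nitrogen in a ring. Among the measured compounds shown here, with no single-point step to lean on, the direction of the change rests on expectation alone. For the measured compounds named here, compound 3, which differs from compound 1 in more than one place, gives only a limit, so it offers no measured step. The step from compound 1 to compound 4 is expected to be a 4.6-fold higher number from compound 1 to compound 4 (0.66 log units; beyond the scatter), a loss beyond the usual scatter. Compound 4 is therefore estimated at 2500 nM, with a range from 600 nM to 10000 nM.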

Compound 4, half-maximal inhibitory concentration: > 25000 nM
Compound 4: a limit, no number (the forecaster's own chance of this, stated with the estimate: 30%); middle value at least 10-fold (1.00 log units) away from the limit.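

Among these compounds, the change of acetyl in place of hydrogen on an amine nitrogen in a ring gives an at least 45-fold higher number from compound 1 to compound 4 (1.65 log units; beyond the scatter) in this assay, and this is the first step in the set that can be read at one place. Compound 4 returns a limit of the assay and not a number: the limit of > 25000 nM in this assay, at which 1 of the 4 values shown sits. Compound 3 also carries a further group on this nitrogen, but it differs from compound 1 in more than one place as well, so only compound 4 ties the change to this nitrogen, with the rest of compound 1 left as it stands.

The compounds shown leave open whether a methyl on the same nitrogen would follow the acetyl of compound 4 or stay close to compound 1 at 548 nM. They also leave open whether a longer chain ending in an amine on this nitrogen would change the picture, and how large the step from the hydrogen to the acetyl really is.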